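The source may report more compounds than this note shows. Statements on the series, on what has been measured and on what is new or still open speak of the compounds shown alone.

Of the compounds shown here, three have been tested in a functional assay on MCF7 cells (Homo sapiens) for cytotoxicity, read by MTT assay, with a stated time of 72 h; a lower number here means a stronger inhibitor, a higher number a weaker inhibitor. Compound 1, with the structure `COc1cc(/C=C/C(=O)c2cc3cc(O)ccc3oc2=O)cc(OC)c1OC`, gives 10900 nM in this assay. Compound 2, with the structure `COc1cccc(/C=C/C(=O)c2cc3cc(O)ccc3oc2=O)c1OC`, gives 8800 nM in this assay. The values of compound 1 and compound 2 lie within the scatter of each other, so no order between them can be read. The difference between the two cores of compound 1 and compound 2 is not broken down here.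

Compound 3, with the structure `COc1cccc(/C=C/C(=O)c2cc3cc(OCc4ccccc4)ccc3oc2=O)c1OC`, gives 21300 nM in this assay. It differs from compound 2 only by the change (benzyl in place of hydrogen on an oxygen on an aromatic ring). That change produced the step of a 2.4-fold higher number from compound 2 to compound 3 (0.38 log units; beyond the scatter), a weakening that goes beyond the usual scatter.

Compound 4, with the structure `COc1cc(/C=C/C(=O)c2cc3cc(OCc4ccccc4)ccc3oc2=O)cc(OC)c1OC`, has not yet been measured in this assay. It differs from compound 1 by the change (benzyl in place of hydrogen on an oxygen on an aromatic ring). This is the same change as the one from compound 2 to compound 3, made at the same kind of place; among these compounds it appears twice in all. Among the compounds with values here, the expectation for compound 4 rests on a single earlier example, because a 2.4-fold higher number from compound 2 to compound 3 (0.38 log units; beyond the scatter) is the only measured instance of this change, so the uncertainty is wide. Carrying that step over, compound 4 is expected to show a weakening of about a 2.3-fold higher number from compound 1 to compound 4 (0.36 log units; beyond the scatter) in this assay. On that basis compound 4 is estimated at 25000 nM in this assay, with a likely range from 12000 nM to 55000 nM.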

Compound 4, half-maximal inhibitory concentration: 26500 nM
For compound 4 the middle estimate is 1.1-fold (0.03 log units) below the measured one, and the stated range covers the measured number.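

In this assay, putting benzyl in place of the hydrogen on the oxygen of the core of compound 1 gives a step of a 2.4-fold higher number from compound 1 to compound 4 (0.39 log units; beyond the scatter), a modest weakening beyond the scatter. The change therefore behaves alike on both cores, raising the number by practically the same amount each time, so in this small series the step measured on one core was a fair guide to the step on the other: the same change on two cores in this assay, a 2.4-fold higher number (0.38 log units; beyond the scatter) from compound 2 to compound 3 and a 2.4-fold higher number (0.39 log units; beyond the scatter) from compound 1 to compound 4, 1.0-fold (0.00 log units) apart, within the scatter of two such steps

Within the data shown here, this agreement rests on only two pairs of closely related compounds in a single cell assay, so it does not show that the step would hold on a more different core, and it does not explain why the benzyl compounds give higher numbers.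

The compounds shown leave open how the number would respond to other groups on that oxygen, such as a methyl, a longer chain, or a chain ending in an amine or a carboxylic acid. They also leave open whether the weakening depends on the aromatic ring of the benzyl group or simply on replacing the hydrogen of the hydroxy group, a question that a compound carrying methyl there could help to separate.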